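Swapping the acyl group of an aryl sulfonate ester

The source may hold more compounds than are shown below. What is called first, only, known or untested is meant among the compounds shown, and "the series" means these compounds.

Measured so far in a functional assay on HT-29 cells (Homo sapiens) for antiproliferative activity, read by sulforhodamine B assay, with a stated time of 48 h; a higher number here means a weaker inhibitor, a lower number a stronger inhibitor:
compound 1 `CCC(=O)Nc1ccc(S(=O)(=O)Oc2ccccc2C(C)C)cc1` gives 7400 nM;
compound 2 `CCCC(=O)Nc1ccc(S(=O)(=O)Oc2ccccc2C(C)C)cc1` gives 4900 nM;
compound 3 `CC(C)c1ccccc1OS(=O)(=O)c1ccc(NC(=O)CCl)cc1` gives 5600 nM.

Compound 3 stands second highest of the three numbers, yet its nearest neighbour is compound 2 and its furthest is compound 1, and both gaps are within the scatter, so the three compounds cannot be ranked against one another on these numbers.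

The next compound, compound 4 `CCNC(=O)Nc1ccc(S(=O)(=O)Oc2ccccc2C(C)C)cc1`, differs from compound 3 in one place: ethylamino in place of chloromethyl on a carbonyl carbon The group that enters sits on a carbonyl carbon whose other neighbour is an amide-type nitrogen, so the change reads (chloromethyl)carbonyl to ethylcarbamoyl.

The steps already measured all touch this same carbonyl-bound position: a 1.5-fold lower number from compound 1 to compound 2 (0.18 log units; within the scatter) a 1.3-fold lower number from compound 1 to compound 3 (0.12 log units; within the scatter) a 1.1-fold higher number from compound 2 to compound 3 (0.06 log units; within the scatter) None of them moved the number beyond the scatter. Going by the values given here, no measured step brings an ethylamino group into this place, so the expectation for compound 4 rests only on the steadiness of the numbers in this assay across the three acyl variants. A step of a 1.1-fold higher number from compound 3 to compound 4 (0.03 log units; within the scatter) is therefore expected, meaning none beyond the scatter. For compound 4 the estimate is 6000 nM, with a range from 2500 nM to 15000 nM.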

Compound 4, half-maximal inhibitory concentration: 1100 nM
The estimate for compound 4 lay 5.5-fold (0.74 log units) above the measured number; measured number below the stated range.
By their numbers in this assay, from the lowest: compound 4; then compounds 2, 3 and 1 (each within the scatter of the next).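

Across the three acyl variants, the number in this assay stayed within the scatter, so this carbonyl-bound position looked insensitive to change. Ethylamino on the carbonyl carbon shows that it is not: there is a 5.1-fold lower number from compound 3 to compound 4 (0.71 log units; beyond the scatter), alongside a 4.5-fold lower number from compound 2 to compound 4 (0.65 log units; beyond the scatter) and a 6.7-fold lower number from compound 1 to compound 4 (0.83 log units; beyond the scatter), so compound 4 stands apart from all three, though each step is modest. Unlike chloromethyl, the entering group carries a nitrogen and one hydrogen-bond donor, but nothing available explains the lower number.

As far as these compounds go, whether the nitrogen or the ethyl chain on it matters remains open, since a methylamino or longer propylamino group on the same carbonyl would help separate the two. A dimethylamino group, which has no hydrogen on its nitrogen, would also test whether that hydrogen is needed.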